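The source may hold more compounds than are shown below. What is called first, only, known or untested is meant among the compounds shown, and "the series" means these compounds.

Compound 1 `Cc1cc(C)c(CN2CCc3c(Cl)cc(-c4c(C)noc4C)c(Cl)c3C2=O)c(=O)[nH]1`: 1.15 nM
Compound 2 `COc1cc(C)[nH]c(=O)c1CN1CCc2c(Cl)cc([C@@H](O)C3COC3)c(Cl)c2C1=O`: 1500 nM
Compound 3 `COc1cc(C)[nH]c(=O)c1CN1CCc2c(Cl)cc(C(OC)C3(C)COC3)c(Cl)c2C1=O`: 350 nM; 0.7 nM (2 entries)
Compound 4 `COc1cc(C)[nH]c(=O)c1CN1CCc2c(Cl)cc(-c3c(C)noc3C)c(Cl)c2C1=O`: not yet measured

Of the compounds shown here, three sharing a common core have been tested in an assay for inhibition of histone-lysine N-methyltransferase EZH2 variant Y641N (Homo sapiens), read by scintillation counting, with a stated time of 60 min, in the presence of a further agent that is not named here; on this read-out higher numbers stand for weaker inhibition and lower numbers for stronger inhibition. Compound 1 gives 1.15 nM. Compound 2 gives 1500 nM, the highest number among the compounds reported with a single value, and far above that of compound 1. Compound 3 has several entries, (the several entries of compound 3 in this assay, 350 nM; 0.7 nM (2 entries)), which spread so widely that it cannot be placed firmly.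

Compound 4 keeps the head group of compound 2 and differs from it at one place: a group of 7 heavy atoms (5 carbon, 1 nitrogen, 1 oxygen; one five-membered aromatic ring with 2 hetero atoms) in place of a group of 6 heavy atoms (4 carbon, 2 oxygen; one four-membered non-aromatic ring with 1 hetero atom), on an aromatic carbon. The same 3,5-dimethyl-1,2-oxazol-4-yl group stands at that place in compound 1, whose value 1.15 nM lies far below the number for compound 2. On that basis the step of a 1000-fold lower number from compound 2 to compound 4 (3.00 log units; beyond the scatter) is expected to be a large fall in the number, well beyond the usual scatter. Compound 4 is therefore estimated at 1.5 nM, within a range from 0.4 nM to 6 nM.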

Compound 4, inhibition constant in the histone-lysine N-methyltransferase EZH2 assay: 0.15 nM
For compound 4 the middle estimate is 10-fold (1.00 log units) above the measured one; the whole stated range lies above it.
By their numbers in the histone-lysine N-methyltransferase EZH2 assay, from the lowest: compound 4; then compound 1; then compound 2.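

In the histone-lysine N-methyltransferase EZH2 assay, the 3,5-dimethyl-1,2-oxazol-4-yl group in place of the group with the four-membered non-aromatic ring gives a 10000-fold lower number from compound 2 to compound 4 (4.00 log units; beyond the scatter), so this aromatic carbon is a place where one change moves the number very far. Within the data shown here, with the 3,5-dimethyl-1,2-oxazol-4-yl group kept, methoxy in place of methyl on an aromatic carbon gives, in the histone-lysine N-methyltransferase EZH2 assay, a 7.7-fold lower number from compound 1 to compound 4 (0.88 log units; beyond the scatter), so the head group matters as well, something no earlier pair could show. In a physicochemical assay for solubility, measured as kinetic solubility (a lower number here means a less soluble compound, a higher number a more soluble compound), compound 2 gives 582000 nM and compound 4 gives 384000 nM, which is a 1.5-fold lower number from compound 2 to compound 4 (0.18 log units; within the scatter), so these two cannot be told apart on this read-out.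

As far as these compounds go, whether an amine, a carboxylic acid or a phenyl ring at this place would behave alike stays open, as does the part played by the two methyl groups. Nothing measured here says why the change acts so strongly.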